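A few compounds are considered here, and "the series" means these few. Any claim that something is new, unique, unknown or untested is made for them only; others in the source may bear on it.

Of the compounds shown here, two on the shared core have numbers so far. Compound 1 `CCN(Cc1nc2cc(C(F)(F)F)ccc2nc1-c1ccccc1)c1ccc(OC(F)(F)F)cc1` carries an ethyl on the nitrogen and a trifluoromethoxyphenyl; in an assay on isolated protein for inhibition of Dihydrofolate reductase (Homo sapiens), read by spectrophotometry (on this read-out lower numbers stand for stronger inhibition and higher numbers for weaker inhibition), compound 1 gives 5000 nM. Compound 2 `C#CCN(Cc1nc2cc(C(F)(F)F)ccc2nc1-c1ccccc1)c1ccc(F)cc1` carries a propargyl on the nitrogen and a fluorophenyl; in this assay compound 2 gives 8000 nM. Within the data shown here, of the two numbers, that of compound 2 is the larger, but the gap to compound 1 lies within the scatter, so the two count as alike; they differ in two places at once, and no single step connects them.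

Compound 3 `C#CCN(Cc1nc2cc(C(F)(F)F)ccc2nc1-c1ccccc1)c1ccc(OC(F)(F)F)cc1` keeps the propargyl of compound 2 and changes the aryl group: trifluoromethoxy in place of fluoro on an aromatic carbon, on an aromatic carbon of a six-membered aromatic ring of carbon only, para to a large group. Among the measured compounds shown here, no measured pair isolates this change. For the measured compounds named here, the only guide is compound 1, which carries the same trifluoromethoxyphenyl and gives 5000 nM in this assay, a number within the scatter of compound 2. The expected step is therefore small, a 1.5-fold lower number from compound 2 to compound 3 (0.16 log units; within the scatter), in no direction beyond the scatter. Compound 3 is estimated at 5500 nM in this assay, within 2000 nM to 15000 nM.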

Compound 3, inhibition constant: 4000 nM
Compound 3: middle estimate off by 1.4-fold (0.14 log units), on the high side, within the range that was stated.
By their numbers in this assay, from the lowest: compounds 3, 1 and 2 (each within the scatter of the next).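

With the propargyl held fixed, 4-fluorophenyl to 4-(trifluoromethoxy)phenyl can now be read as a single change in this assay, on an aromatic carbon of a six-membered aromatic ring of carbon only, para to a large group (a 2.0-fold lower number from compound 2 to compound 3 (0.30 log units; within the scatter)), so exchanging 1 heavy atom for 5 heavy atoms there leaves the number within the scatter. With the 4-(trifluoromethoxy)phenyl held fixed, the group on the nitrogen also gets its first single-place reading, ethynyl in place of methyl on a saturated chain carbon bound to a nitrogen on an aromatic ring (a 1.3-fold lower number from compound 1 to compound 3 (0.10 log units; within the scatter)), and this step also stays within the scatter. No measurement here accounts for the size of either step.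

Only fluoro and trifluoromethoxy have been compared on this aromatic carbon, and only ethyl and propargyl on the nitrogen, all on the shared core. As far as these compounds go, whether an amine or a carboxylic acid on the aromatic carbon, or a longer chain on the nitrogen, would move the number beyond the scatter remains open.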